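Replacing a Whole Aromatic Ring with a Methyl Group

A few compounds are considered here, and "the series" means these few. Any claim that something is new, unique, unknown or untested is made for them only; others in the source may bear on it.

In an ADME assay on HEp-2 cells (Homo sapiens) for cytotoxicity, read by MTT assay, with a stated time of 3 days (on this read-out higher numbers stand for lower toxicity in this test and lower numbers for higher toxicity in this test), compound 1 `c1ccc(C[C@@H](CCn2cncn2)c2ccccc2)cc1` gives 55.9 ug/mL and compound 2 `COc1ccc([C@H](CCn2cncn2)Cc2ccccc2)cc1` gives 60.3 ug/mL. Compound 3 `Cc1ccc([C@H](CCn2cncn2)Cc2ccccc2)cc1` gives 152 ug/mL, the highest of the three numbers, which makes it the least toxic of them in this test.

Compound 4 `C[C@H](CCn1cncn1)Cc1ccccc1` is still unmeasured. It carries methyl in place of 4-methylphenyl on a saturated chain carbon bound to two saturated chain carbons.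

The measured steps are only small swaps on an aromatic ring. One is a 1.1-fold higher number from compound 1 to compound 2 (0.03 log units; within the scatter), within the scatter. Two are modest: a 2.7-fold higher number from compound 1 to compound 3 (0.43 log units; beyond the scatter) and a 2.5-fold higher number from compound 2 to compound 3 (0.40 log units; beyond the scatter). None of them removes a ring, so they guide this far larger change only loosely. Since compound 3 stands at the top of a narrow span, a slight fall is the cautious expectation, with no step beyond the scatter.

The expected change is a 1.6-fold lower number from compound 3 to compound 4 (0.20 log units; within the scatter). For compound 4 the estimated value is 95 ug/mL, with an expected range from 35 ug/mL to 280 ug/mL.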

Compound 4, half-maximal cytotoxic concentration: 144 ug/mL
Estimate against measurement, compound 4: 1.5-fold (0.18 log units) below, within the range that was stated.
By their numbers in this assay, from the lowest: compounds 1 and 2 (each within the scatter of the next); then compounds 4 and 3 (each within the scatter of the next).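

At this saturated chain carbon, methyl can take the place of the whole 4-methylphenyl group, and this assay records only a 1.1-fold lower number from compound 3 to compound 4 (0.02 log units; within the scatter) for the loss of that aromatic ring. So an aromatic ring at this position is not needed for a high number, which the earlier ring swaps could not show, and methyl in place of plain phenyl gives a 2.6-fold higher number from compound 1 to compound 4 (0.41 log units; beyond the scatter) as the same carbon's other comparison. Nothing available here explains why these two replacements read differently.

Going by these compounds, what a longer chain, such as propyl, or an amine or a carboxylic acid would give at this carbon stays open. So does whether methyl at this position would read the same with a different group on the remaining phenyl ring.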